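Trifluoromethyl to Hydrogen on Two Weakly Cytotoxic Cores

A few compounds are considered here, and "the series" means these few. Any claim that something is new, unique, unknown or untested is made for them only; others in the source may bear on it.

Compound 1 `COc1ccc(Cn2nc(-c3ccccc3)c3cc(C(=N)Nc4cccc(C(F)(F)F)c4)nc(Nc4cc(OC)c(OC)c(OC)c4)c32)cc1` was examined in a functional assay on MDA-MB-231 cells (Homo sapiens) for cytotoxicity, read by MTT assay, with a stated time of 72 h; a lower number here means a stronger inhibitor, a higher number a weaker inhibitor. Compound 1 gives only a limit there, > 50000 nM. Compound 2 `COc1ccc(Cn2nc(-c3ccccc3)c3cc(C(=N)Nc4ccccc4)nc(Nc4cc(OC)c(OC)c(OC)c4)c32)cc1` differs from compound 1 by hydrogen in place of trifluoromethyl on an aromatic carbon. In this assay compound 2 gives 42100 nM. The step of an at least 1.1-fold lower number from compound 1 to compound 2 (0.07 log units; that floor lies within the scatter) lies within the scatter, and its size can be stated only as a floor because of the limit of > 50000 nM in this assay, at which 2 of the 3 values shown sit.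

Compound 3 `Cn1ncc2cc(C(=N)Nc3cccc(C(F)(F)F)c3)ncc21` is built on a much smaller core; the difference between the two cores is not broken down here. In this assay compound 3 likewise gives only a limit, > 50000 nM. Compound 4 `Cn1ncc2cc(C(=N)Nc3ccccc3)ncc21` has not yet been measured; it differs from compound 3 by hydrogen in place of trifluoromethyl on an aromatic carbon, the same change that separates compound 1 from compound 2.

For compound 4 a step that the limit leaves unreadable from compound 3 to compound 4 is expected, resting on the small measured step of an at least 1.1-fold lower number from compound 1 to compound 2 (0.07 log units; that floor lies within the scatter) seen on the larger core. Compound 4 is therefore estimated at 55000 nM in this assay, with a good chance that a limit rather than a number is reported again.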

Compound 4, half-maximal inhibitory concentration: > 50000 nM
Compound 4: only a limit was reported (the forecaster's own chance of this, stated with the estimate: 70%); the middle value does not contradict the limit.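

No step from compound 3 to compound 4 can be read in this assay, because both compounds give only a limit: the limit of > 50000 nM in this assay, at which 3 of the 4 values shown sit.

The compounds shown leave open whether hydrogen in place of trifluoromethyl alters cytotoxicity on the smaller core of compound 3 at all, and how its effect there compares with that on the larger core.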